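A Trifluoromethoxyphenyl Variant in the Bile Acid Receptor Series

A few compounds are considered here, and "the series" means these few. Any claim that something is new, unique, unknown or untested is made for them only; others in the source may bear on it.

Within the data shown here, compound 3 `COC(=O)/C=C/c1cccc(N(Cc2ccc(-c3cc(Cl)ccc3OC)cc2)C(=O)C2CCCCC2)c1` gives 233 nM in an assay on isolated protein with Bile acid receptor (Homo sapiens) as the target (on this read-out lower numbers stand for an effect already at smaller amounts and higher numbers for an effect only at larger amounts of compound), the highest number among the three compounds measured so far. Compound 1 `COC(=O)/C=C/c1cccc(N(Cc2ccc(-c3cccc(C)c3)cc2)C(=O)C2CCCCC2)c1` gives 109 nM, and compound 2 `COC(=O)/C=C/c1cccc(N(Cc2ccc(-c3ccc(SC)cc3)cc2)C(=O)C2CCCCC2)c1` gives 69 nM. The measured steps show a 2.1-fold higher number from compound 1 to compound 3 (0.33 log units; beyond the scatter) and a 3.4-fold higher number from compound 2 to compound 3 (0.53 log units; beyond the scatter), while a 1.6-fold lower number from compound 1 to compound 2 (0.20 log units; within the scatter). Compound 4 `COC(=O)/C=C/c1cccc(N(Cc2ccc(-c3ccc(OC(F)(F)F)cc3)cc2)C(=O)C2CCCCC2)c1` carries the change (4-(trifluoromethoxy)phenyl in place of 5-chloro-2-methoxyphenyl on an aromatic carbon). Both steps that end at compound 3 bear on this change: each exchanges the 5-chloro-2-methoxyphenyl group for another aryl group, and each raised the number. Reversing that exchange is therefore expected to lower the number, and the expected step is a 2.7-fold lower number from compound 3 to compound 4 (0.44 log units; beyond the scatter). The value for compound 4 is estimated at 85 nM, with a range from 40 nM to 180 nM.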

Compound 4, half-maximal effective concentration: 264 nM
Estimate against measurement, compound 4: 3.1-fold (0.49 log units) below, outside the stated range (above it).
By their numbers in this assay, from the lowest: compounds 2 and 1 (each within the scatter of the next); then compounds 3 and 4 (each within the scatter of the next).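

In this assay, 4-(trifluoromethoxy)phenyl in place of 5-chloro-2-methoxyphenyl gives a 1.1-fold higher number from compound 3 to compound 4 (0.05 log units; within the scatter), so this position does not separate these two aryl groups. The higher numbers are thus not confined to 5-chloro-2-methoxyphenyl: trifluoromethoxy in place of methylsulfanyl alone gives a 3.8-fold higher number from compound 2 to compound 4 (0.58 log units; beyond the scatter), and 4-(trifluoromethoxy)phenyl in place of 3-methylphenyl gives a 2.4-fold higher number from compound 1 to compound 4 (0.38 log units; beyond the scatter). Nothing available explains why these aryl groups differ in this way. The compounds shown leave open how an amine or a carboxylic acid on this aryl ring would read out, and whether methylsulfanyl's result extends to a longer thioether chain.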